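Cyano Added to the Biaryl of Compound 2

The compounds below may be only part of what the source reports. "The series", "measured", "known", "first", "only" and "open" are said of these compounds alone.

Compound 1, `CS(=O)(=O)c1cc(Cl)c(NC(=O)N2CCN3C(=O)N([C@H]4C[C@@H]4c4ccccc4)C(=O)[C@@H]3C2)c(Cl)c1`: 0.6 L/kg
Compound 2, `O=C(Nc1cccnc1-c1ccccc1)N1CCN2C(=O)N([C@H]3C[C@@H]3c3ccccc3)C(=O)[C@@H]2C1`: 6.7 L/kg

In an in vivo ADME assay on the whole organism for pharmacokinetics, with Rattus norvegicus as the target (on this read-out higher numbers stand for wider distribution into tissues and lower numbers for narrower distribution), compound 2 gives 6.7 L/kg, the higher of the two numbers, while compound 1 gives 0.6 L/kg, a gap well beyond the usual scatter. Compound 3, `N#Cc1cccc(-c2ncccc2NC(=O)N2CCN3C(=O)N([C@H]4C[C@@H]4c4ccccc4)C(=O)[C@@H]3C2)c1`, differs from compound 2 by cyano in place of hydrogen on an aromatic carbon. For the measured compounds named here, no measured pair shows this change, so the size of the step is uncertain; a small decrease, possibly within the scatter, is expected. Compound 3 is estimated at 4 L/kg, within 1.5 L/kg to 9 L/kg. The expected step is a 1.7-fold lower number from compound 2 to compound 3 (0.22 log units; within the scatter).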

Compound 3, volume of distribution at steady state: 6 L/kg
For compound 3 the middle estimate is 1.5-fold (0.18 log units) below the measured one, and the stated range covers the measured number.
By their numbers in this assay, from the lowest: compound 1; then compounds 3 and 2 (each within the scatter of the next).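

Replacing phenyl with 3-cyanophenyl is the only single-place change shown, and in this assay it gives a 1.1-fold lower number from compound 2 to compound 3 (0.05 log units; within the scatter), so the two compounds cannot be told apart on this read-out. This aromatic carbon therefore accepts a cyano group with no measurable shift in volume of distribution in the rat. Nothing measured here offers an explanation for this result.

On these data alone, whether an amine or a carboxylic acid at this same position would also leave the number in place remains open. One pair also cannot show whether cyano would behave the same way on another scaffold.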